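The source may hold more compounds than are shown below. What is called first, only, known or untested is meant among the compounds shown, and "the series" means these compounds.

Compound 1 `C=CCn1c(SCC(=O)Nc2ccc(C(C)=O)cc2)nnc1-c1ccccc1` — 63%
Compound 2 `COc1cc(-c2nnc(SCC(=O)Nc3ccc(C(C)=O)cc3)n2-c2ccccc2)cc(OC)c1OC` — 63%
Compound 3 `CCn1c(SCC(=O)Nc2ccc(C(C)=O)cc2)nnc1-c1ccccc1` — 66%

In a functional assay on the whole organism (strain albino) for inhibition, with Rattus norvegicus as the target, read by paw edema, with stated times of 30 min and 5 h, at a dose of 0.28 mmol/kg by the oral route (on this read-out lower numbers stand for less inhibition and higher numbers for more inhibition at the one dose given (going by the name of the read-out)), compound 3 gives the highest of the three numbers, though its gaps to compound 1 and to compound 2 both lie within the scatter, so it cannot be set apart from them. Within the data shown here, the only step with a single change is a number 3 percentage points higher from compound 1 to compound 3 (within the scatter), a small one within the scatter, and it concerns the same chain on the aromatic nitrogen.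

Compound 4 `CC(=O)c1ccc(NC(=O)CSc2nnc(-c3ccccc3)n2-c2ccccc2)cc1` has not yet been measured. It differs from compound 3 in one place: phenyl in place of ethyl on an aromatic nitrogen. No step is shown for this particular exchange. Compound 2, however, already carries a phenyl on its aromatic nitrogen and in this assay gives 63%, which sits within the scatter of compound 3. Because a number 3 percentage points higher from compound 1 to compound 3 (within the scatter) was within the scatter, a change at the same nitrogen is expected to leave the number essentially where it is. Compound 4 is therefore estimated at 63%, ranging from 53% to 73%. The expected step is a number 3 percentage points lower from compound 3 to compound 4 (within the scatter), with no change beyond the scatter.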

Compound 4, a percentage reported as inhibition, in the whole organism at one dose (the size of the read-out at that dose, not a potency): 63%
The estimate for compound 4 equals the measured number at the digits printed, and the stated range covers the measured number.
By their numbers in this assay, from the lowest: compounds 1, 2, 4 and 3 (each within the scatter of the next).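

In this assay, phenyl on the aromatic nitrogen brings a six-membered aromatic ring where ethyl had only two carbons, yet the exchange gives a number 3 percentage points lower from compound 3 to compound 4 (within the scatter) and so stays within the scatter. Set against allyl at the same nitrogen, phenyl gives no change at the digits printed from compound 1 to compound 4 (within the scatter) and again stays within the scatter, so ethyl, allyl and phenyl cannot be told apart at this position. With phenyl on the nitrogen, the group on the aromatic carbon can now be read in a single exchange, and no change at the digits printed from compound 2 to compound 4 (within the scatter) shows that phenyl and 3,4,5-trimethoxyphenyl cannot be told apart there either.

Nothing available explains why these exchanges stay within the scatter. From the compounds shown here alone, it remains open whether an amine, a carboxylic acid or a longer chain on this nitrogen would move the number beyond the scatter.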